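Swapping the Sulfonyl Aryl Group on a Sulfonylated Quinolone

A few compounds are considered here, and "the series" means these few. Any claim that something is new, unique, unknown or untested is made for them only; others in the source may bear on it.

Compound 1 `COc1ccc(-c2cc(=O)c3c(OC)cc(OC)cc3[nH]2)cc1` was tested in a functional assay on SUP-B15 cells (Homo sapiens) for antiproliferative activity, with a stated time of 72 h (a lower number here means that less compound is needed, a higher number that more compound is needed for the effect), and compound 1 reached only the limit of > 62000 nM. Compound 2 `COc1ccc(-c2cc(=O)c3c(OC)cc(OC)cc3n2S(=O)(=O)c2ccc(C)c([N+](=O)[O-])c2)cc1`, which carries a sulfonyl group on the ring nitrogen, likewise reached only the limit of > 51700 nM in this assay. Compound 2 thus stands at the limit of > 51700 nM in this assay, at which 1 of the 2 values shown sits, with no numerical potency known. Compound 3 `COc1ccc(-c2cc(=O)c3c(OC)cc(OC)cc3n2S(=O)(=O)c2ccc(OC)cc2)cc1` differs from compound 2 by 4-methoxyphenyl in place of 4-methyl-3-nitrophenyl on a sulfonyl sulfur. With both measured compounds at limits, no step beyond the scatter is expected in this assay, so an at least 1.0-fold lower number from compound 2 to compound 3 (0.01 log units; that floor lies within the scatter) is expected to be flat. Compound 3 is estimated at 50000 nM, in a range from 10000 nM to 100000 nM.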

Compound 3, half-maximal effective concentration: > 82700 nM
Compound 3 gave a limit, no number; the forecaster's own chance of this, stated with the estimate: 85%; middle value at least 1.6-fold (0.21 log units) from the limit.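

Compound 3 gave only a limit, as did compound 1 and compound 2, so the steps to compound 3 from compound 1 and compound 2 cannot be read. From the compounds shown here alone, whether swapping the sulfonyl aryl group changes potency in this assay stays open.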